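This account rests on a few compounds, and the source may have more. Where it says the series, first, only, none or still open, it means among the compounds named here.

Compound 1 `COc1ccc(S(=O)(=O)Oc2ccccc2/C=C(\C#N)C(=O)Nc2nnc(-c3cccs3)s2)cc1` gives 5230 nM
Compound 2 `COc1ccc(S(=O)(=O)Nc2cccc(/C=C(\C#N)C(=O)Nc3nnc(-c4cccs4)s3)c2)cc1` gives 8370 nM

These two values come from a functional assay on HL-60 cells (Homo sapiens) for inhibition, read by CCK-8 assay, with a stated time of 48 h; on this read-out higher numbers stand for weaker inhibition and lower numbers for stronger inhibition. Compound 1 stands within the usual scatter of compound 2, so the two numbers cannot be told apart and offer a level of activity rather than a ranking.

Compound 3 `COc1ccc(Cc2nnc(NC(=O)/C(C#N)=C/c3ccccc3OS(=O)(=O)c3ccc(OC)cc3)s2)cc1` keeps the core of compound 1 and changes one group, with 4-methoxybenzyl in place of thiophen-2-yl on an aromatic carbon. Among the compounds with values here, no measured pair here tests this kind of change, so the expectation is a cautious one. In this assay no step beyond the scatter is expected, in either direction, and the range is kept wide. The estimated change is a 1.0-fold lower number from compound 1 to compound 3 (0.02 log units; within the scatter). For compound 3 the estimated value is 5000 nM, with an expected range from 1500 nM to 16000 nM.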

Compound 3, half-maximal inhibitory concentration: 3120 nM
The estimate for compound 3 lay 1.6-fold (0.20 log units) above the measured number, and the stated range covers the measured number.
By their numbers in this assay, from the lowest: compounds 3, 1 and 2 (each within the scatter of the next, the first and the last beyond it).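

In this assay, putting 4-methoxybenzyl in place of thiophen-2-yl on the aromatic carbon gives a 1.7-fold lower number from compound 1 to compound 3 (0.22 log units; within the scatter) and so shows that this position can take a group of 9 heavy atoms instead of 5 with no step beyond the scatter. Compounds 1 and 2 both carry thiophen-2-yl here, so they could say nothing about this position, whereas compound 3 shows that a six-membered carbon ring attached through a benzyl group keeps activity at the same level. Nothing measured here explains why the level holds across this change.

Going by these compounds, it remains open how this position responds to a group without an aromatic ring, such as an amine or a longer alkyl chain, or to a carboxylic acid. The same change on the core of compound 2 is also an open question.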